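Trimming an Isopropoxy Chain to Ethoxy on a Shared Core

This account rests on a few compounds, and the source may have more. Where it says the series, first, only, none or still open, it means among the compounds named here.

Compound 1 `COc1cc(C(=O)Nc2cc(OC(F)(F)F)ccc2-n2cncn2)ccc1OC(C)C`: 890 nM
Compound 2 `COc1cc(C(=O)Nc2cc(OC(F)(F)F)ccc2-n2cncn2)ccc1OC1CCC1`: 1000 nM; 1000 nM (2 entries)
Compound 3 `COc1cc(OCC(=O)Nc2cc(OC(F)(F)F)ccc2-n2cncn2)ccc1OC1COC1`: 263 nM; 263 nM (2 entries)

All three were tested in a functional assay on HEK cells for negative allosteric modulation of metabotropic glutamate receptor 7 (Rattus norvegicus), read by calcium flux; on this read-out higher numbers stand for weaker inhibition and lower numbers for stronger inhibition. Compound 1 carries the only single entry; compounds 2 and 3 each have two entries that agree with each other. Compound 1 gives 890 nM and compound 2 gives 1000 nM; 1000 nM (2 entries), two numbers within the usual scatter of each other. Compound 3 gives 263 nM; 263 nM (2 entries), a lower number than compound 1 shows. Compound 4 `CCOc1ccc(C(=O)Nc2cc(OC(F)(F)F)ccc2-n2cncn2)cc1OC` has not yet been measured. It differs from compound 1 by hydrogen in place of methyl on a saturated chain carbon bound to an oxygen on an aromatic ring and a saturated chain carbon. Within the data shown here, no measured pair shows this change, so no step size is known from the data; for so small a trim of an alkoxy chain the expected step is a 1.2-fold higher number from compound 1 to compound 4 (0.09 log units; within the scatter), within the scatter. Compound 4 is estimated at 1100 nM, between 450 nM and 2700 nM.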

Compound 4, half-maximal inhibitory concentration: 550 nM
Estimate against measurement, compound 4: 2.0-fold (0.30 log units) above; measured number inside the range.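

In this assay, among these compounds, cutting isopropoxy back to ethoxy gives a 1.6-fold lower number from compound 1 to compound 4 (0.21 log units; within the scatter) and so provides the first measured step at this position. Removing this one methyl from a saturated chain carbon leaves the number within the usual scatter, so on this read-out the shared core accepts either chain. No supporting measurement is available to explain this result. On these data alone, whether a longer chain such as butoxy, or an amine or a hydroxyl on that chain carbon, would shift the number stays open.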